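A few compounds are considered here, and "the series" means these few. Any claim that something is new, unique, unknown or untested is made for them only; others in the source may bear on it.

Among the measured compounds shown here, compound 3 `CCOC(=O)Nc1cccc(-c2csc(NC(=O)CCCCCC(=O)NO)n2)c1` gives the only plain number in an assay on isolated protein for inhibition of protein deacetylase HDAC6 (Homo sapiens), read by fluorescence, with a stated time of 17 h (a higher number here means a weaker inhibitor, a lower number a stronger inhibitor), namely 0.79 nM. Compound 2 `CC(C)(C)OC(=O)Nc1cccc(-c2csc(NC(=O)CCCCCC(=O)NO)n2)c1` sits at a limit of this assay, reported as < 0.17 nM. Compound 1 `Nc1cccc(-c2csc(NC(=O)CCCCCC(=O)Nc3ccccc3N)n2)c1` likewise sits at a limit of this assay, reported as > 30000 nM. For the measured compounds named here, the single measured step, an at least 4.6-fold higher number from compound 2 to compound 3 (0.66 log units; beyond the scatter), moved the number upward. Compound 4 `Nc1cccc(-c2csc(NC(=O)CCCCCC(=O)NO)n2)c1` differs from compound 3 by hydrogen in place of ethoxycarbonyl on a nitrogen on an aromatic ring. Going by the values given here, no measured step covers exactly this change; the step of an at least 4.6-fold higher number from compound 2 to compound 3 (0.66 log units; beyond the scatter) bears on it only in that shortening the group on this nitrogen weakened inhibition, so a further modest weakening is expected, with an estimated step of a 3.8-fold higher number from compound 3 to compound 4 (0.58 log units; beyond the scatter). Compound 4 is accordingly estimated at 3 nM in this assay, within a range from 0.5 nM to 20 nM.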

Compound 4, half-maximal inhibitory concentration: 3.3 nM
Compound 4: middle estimate off by 1.1-fold (0.04 log units), on the low side; the measured number falls inside the stated range.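

In this assay, hydrogen in place of ethoxycarbonyl on the nitrogen gives a 4.2-fold higher number from compound 3 to compound 4 (0.62 log units; beyond the scatter), so inhibition persists with the bare amino group, though weaker. Across the groups tested on this nitrogen, the change from tert-butoxycarbonyl to hydrogen gives an at least 19-fold higher number from compound 2 to compound 4 (1.28 log units; beyond the scatter), a bound only, as compound 2 stands at a limit: the limit of < 0.17 nM in this assay, at which 1 of the 4 values shown sits. With the amino group kept, hydroxy in place of 2-aminophenyl gives an at least 9000-fold lower number from compound 1 to compound 4 (3.95 log units; beyond the scatter), again a bound, as compound 1 stands at a limit: the limit of > 30000 nM in this assay, at which 1 of the 4 values shown sits.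

As far as these compounds go, whether an acetyl or a methyl group on this nitrogen would fall nearer compound 3 or compound 4 remains open. So does the effect of a shorter or longer chain in the linker.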